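The compounds below may be only part of what the source reports. "The series", "measured", "known", "first", "only" and "open" are said of these compounds alone.

Measured so far:
- compound 1, `O=C1C=C(N2CCC2)C(=O)c2c1nc1n2[C@H]2OC[C@@H](O)[C@H]2OC1`: > 16000 nM
- compound 2, `O=C1C(NC2CCCCC2)=CC(=O)c2c1nc1n2[C@H]2OC[C@@H](O)[C@H]2OC1`: > 16000 nM

Compound 1 was tested in a functional assay on ECa-109 cells for inhibition, with ECa-109 cell line (Homo sapiens) as the target, read by sulforhodamine B assay (a higher number here means a weaker inhibitor, a lower number a stronger inhibitor), where compound 1 gives > 16000 nM, a value that is only a limit of the assay and not a number. Compound 2 likewise gives > 16000 nM in this assay, again a limit rather than a number. So compound 1 stands at the limit of > 16000 nM in this assay, at which 2 of the 2 values shown sit, and nothing measured here separates it from compound 2 beyond the fact that both sit at that limit.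

Compound 3, `COc1cccc(NC2=CC(=O)c3nc4n(c3C2=O)[C@H]2OC[C@@H](O)[C@H]2OC4)c1`, has not yet been measured in this assay. It differs from compound 1 in one place: (3-methoxyphenyl)amino in place of azetidin-1-yl on a double-bonded ring carbon. For the measured compounds named here, since no measured step is available to guide the size of this change, the expectation is modest: a small gain at most, possibly none beyond the scatter, is expected in an at least 1.3-fold lower number from compound 1 to compound 3 (0.12 log units; that floor lies within the scatter), and the assay may again report only a limit. Compound 3 is estimated at 12000 nM, within a range from 3000 nM to 40000 nM.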

Compound 3, half-maximal inhibitory concentration: 7620 nM
Estimate against measurement, compound 3: 1.6-fold (0.20 log units) above, within the range that was stated.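

In this assay, (3-methoxyphenyl)amino in place of azetidin-1-yl on a double-bonded ring carbon gives an at least 2.0-fold lower number from compound 1 to compound 3 (0.32 log units; beyond the scatter), so the group at this place can change the result beyond the usual scatter. Compound 1 gives > 16000 nM, which is a limit and not a number, so the full size of this step cannot be read. Compound 3 is the first compound here with a true number rather than a limit, and the other values shown stay at that limit: the limit of > 16000 nM in this assay, at which 2 of the 3 values shown sit.

Going by these compounds, what remains open is which part of the entering group matters: the aromatic ring, the methoxy group or the amino hydrogen. A plain phenylamino group, or a hydroxy group in place of the methoxy group, would help to separate these parts.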